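The source may hold more compounds than are shown below. What is called first, only, known or untested is meant among the compounds shown, and "the series" means these compounds.

In a functional assay on NCI-H460 cells (Homo sapiens) for cytotoxicity, read by MTT assay, with a stated time of 72 h (a higher number here means a weaker inhibitor, a lower number a stronger inhibitor), compound 1 (`CCCCCCCCNC1=CC(=O)C=C(C[C@]2(C)[C@@H](C)CC[C@]3(C)C(C)=CCC[C@@H]23)C1=O`) gives 38000 nM and compound 3 (`CCNC1=CC(=O)C(C(C)(C)C)=CC1=O`) gives 64000 nM, two values within the scatter of each other. Compound 2 (`CC(C)(C)C1=CC(=O)C=C(NCc2ccccc2)C1=O`) gives 14000 nM, a number beyond the scatter from that of compound 3. Compound 4 (`CCCCNC1=CC(=O)C(C(C)(C)C)=CC1=O`) departs from compound 3 by one change: ethyl in place of hydrogen on a saturated chain carbon, two bonds along the chain from an amine nitrogen. This places ethyl in place of hydrogen on a saturated chain carbon, two bonds along the chain from an amine nitrogen, so ethylamino becomes butylamino. Among the measured compounds shown here, no measured pair isolates such a change, so in this assay only a small drift toward a lower number is expected, probably none beyond the scatter. The expected step runs a 1.8-fold lower number from compound 3 to compound 4 (0.26 log units; within the scatter). Compound 4 is estimated at 35000 nM, with an expected range of 15000 nM to 70000 nM.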

Compound 4, half-maximal inhibitory concentration: 36000 nM
Compound 4: middle estimate off by 1.0-fold (0.01 log units), on the low side; the range from low to high includes it.
By their numbers in this assay, from the lowest: compound 2; then compounds 4, 1 and 3 (each within the scatter of the next).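

In this assay, among the compounds shown here, the step of a 1.8-fold lower number from compound 3 to compound 4 (0.25 log units; within the scatter) is the only reading so far of this change, ethylamino to butylamino, and it stays within the scatter. Ethyl in place of hydrogen on this saturated chain carbon therefore leaves the two compounds indistinguishable in this cell assay. Nothing available here bears on the reason for this result. The compounds shown leave open whether a hexyl chain at this place would also stay within the scatter of compound 4. They also leave open what a terminal hydroxyl or carboxylic acid on the butyl chain would do.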